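Replacing 3-nitrobenzyl with 4-bromobenzyl on the sulfur

The compounds below may be only part of what the source reports. "The series", "measured", "known", "first", "only" and "open" are said of these compounds alone.

Measured in a functional assay on SW-620 cells (Homo sapiens) for cytotoxicity, read by MTT assay, with stated times of 4 h and 72 h, tested at 5 uM; on this read-out lower numbers stand for stronger inhibition and higher numbers for weaker inhibition:
- compound 1 `Cc1cc(Nc2ccc(C(=O)/C=C/c3ccc4ccccc4c3)cc2)n2nc(SCc3ccc([N+](=O)[O-])cc3)nc2n1`: 1130 nM
- compound 2 `Cc1cc(Nc2ccc(C(=O)/C=C/c3ccc4ccccc4c3)cc2)n2nc(SCc3cccc([N+](=O)[O-])c3)nc2n1`: 790 nM

For the measured compounds named here, on these numbers, compound 2 cannot be told apart from compound 1, its only measured neighbour. Going by the values given here, the single measured step is a 1.4-fold lower number from compound 1 to compound 2 (0.16 log units; within the scatter), and it exchanges 4-nitrophenyl for 3-nitrophenyl on a saturated chain carbon bound to a sulfur.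

Compound 3 `Cc1cc(Nc2ccc(C(=O)/C=C/c3ccc4ccccc4c3)cc2)n2nc(SCc3ccc(Br)cc3)nc2n1` has not yet been measured. It keeps the shared core of compound 2 but carries 4-bromophenyl in place of 3-nitrophenyl on a saturated chain carbon bound to a sulfur.

The step from compound 1 to compound 2 bears on this change only partly, as it swaps one nitrophenyl for another, whereas here the nitrophenyl leaves altogether. Among the compounds with values here, no measured compound carries 4-bromophenyl, so the data give no firm direction. In this assay, no change beyond the scatter is therefore expected. The expected step is a 1.3-fold higher number from compound 2 to compound 3 (0.10 log units; within the scatter). For compound 3 the estimated value is 1000 nM, with an expected range from 400 nM to 2500 nM.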

Compound 3, half-maximal inhibitory concentration: 370 nM
For compound 3 the middle estimate is 2.7-fold (0.43 log units) above the measured one; the whole stated range lies above it.
By their numbers in this assay, from the lowest: compound 3; then compounds 2 and 1 (each within the scatter of the next).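

In this assay, the group on the sulfur can shift the number beyond the scatter, something the exchange between the two nitrophenyl groups alone did not show. Placing 4-bromophenyl in place of 3-nitrophenyl on a saturated chain carbon bound to a sulfur gives a modest change (a 2.1-fold lower number from compound 2 to compound 3 (0.33 log units; beyond the scatter)), and bromo in place of nitro on an aromatic carbon gives another modest change (a 3.1-fold lower number from compound 1 to compound 3 (0.48 log units; beyond the scatter)), so compound 3, which carries no nitro group, has the lowest number of the three. The position therefore responds to what the aromatic ring carries, and a nitro group is not required for a number of this size, although nothing at hand accounts for the difference.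

These compounds do not separate a contribution of the bromine from the departure of the nitro group, and a plain benzyl, 4-chlorobenzyl or 4-methoxybenzyl on the sulfur would bear directly on that question. They also leave open whether the place of the bromine on the ring matters, as 3-bromobenzyl would test against compound 3.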